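The compounds below may be only part of what the source reports. "The series", "measured", "known", "first", "only" and "open" are said of these compounds alone.

Compound 1 `Nc1nc2ccccn2c1-c1ccc(O)cc1` gives in an assay on isolated protein for inhibition of ubiquitin carboxyl-terminal hydrolase 47 (Homo sapiens) (on this read-out lower numbers stand for stronger inhibition and higher numbers for weaker inhibition), only the limit > 100000 nM. Compound 2 `Nc1nc2ccc(C(F)(F)F)cn2c1-c1ccc(O)cc1` gives in this assay only the limit > 100000 nM.

On the numbers shown, compound 2 stands at the limit of > 100000 nM in this assay, at which 2 of the 2 values shown sit, so no real number is known for it. The change methyl in place of trifluoromethyl on an aromatic carbon leads to compound 3 `Cc1ccc2nc(N)c(-c3ccc(O)cc3)n2c1`. For the measured compounds named here, the only measured step that bears on this exchange is a step that the two limits leave unreadable from compound 1 to compound 2, and its size cannot be read, so no direction can be drawn from it. Compound 3 is therefore expected to stay near the limit, estimated at 100000 nM, within 30000 nM to 300000 nM. This estimate means an expected step of a number no higher from compound 2 to compound 3 (the limit leaves the size open).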

Compound 3, half-maximal inhibitory concentration: > 100000 nM
Compound 3: a limit, no number; the forecaster's own chance of this, stated with the estimate: 85%; the middle value sits exactly at the limit.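

Compound 1, compound 2 and compound 3 all give only a limit in this assay, so no step among them can be read: the limit of > 100000 nM in this assay, at which 3 of the 3 values shown sit.

The compounds shown leave open whether hydrogen, methyl or trifluoromethyl on this aromatic carbon makes any difference.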